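A Third Methoxy Group on the Core of Compound 3

A few compounds are considered here, and "the series" means these few. Any claim that something is new, unique, unknown or untested is made for them only; others in the source may bear on it.

Compound 1 `COc1ccc(/C=C/C(=O)c2ccccc2-c2ccc(F)nc2)cc1` gives 160 nM in a functional assay on CNE-2 cells (Homo sapiens) for antiproliferative activity, read by sulforhodamine B assay, with a stated time of 48 h; on this read-out lower numbers stand for stronger inhibition and higher numbers for weaker inhibition. Compound 2 `COc1ccc(/C=C/C(=O)c2ccccc2-c2ccc(F)nc2)cc1OC` differs from it by methoxy in place of hydrogen on an aromatic carbon; in this assay compound 2 gives 1600 nM, which is a 10-fold higher number from compound 1 to compound 2 (1.00 log units; beyond the scatter). Compound 3 `COc1ccc(C(=O)/C=C/c2ccccc2-c2ccc(F)cc2)cc1OC` rests on a different core, and the difference between the two cores is not broken down here; in this assay compound 3 gives 7600 nM, the highest of the three numbers. Compound 4 `COc1cc(C(=O)/C=C/c2ccccc2-c2ccc(F)cc2)cc(OC)c1OC` differs from compound 3 by methoxy in place of hydrogen on an aromatic carbon. This is the same kind of change as that from compound 1 to compound 2, though here the entering group is also meta to a methoxy group. Because of a 10-fold higher number from compound 1 to compound 2 (1.00 log units; beyond the scatter), a higher number is expected for compound 4 on the new core as well, though with less confidence given the different surroundings. The expected step is a 2.4-fold higher number from compound 3 to compound 4 (0.37 log units; beyond the scatter). For compound 4 the estimate is 18000 nM, between 5000 nM and 60000 nM.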

Compound 4, half-maximal inhibitory concentration: 3800 nM
Compound 4: middle estimate off by 4.7-fold (0.68 log units), on the high side, outside the stated range (below it).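

In this assay the added methoxy group gives a 2.0-fold lower number from compound 3 to compound 4 (0.30 log units; within the scatter) and so leaves no difference on this core that stands clear of repeat measurement. The same change therefore does not carry over in size or direction from the core of compound 1 to the core of compound 3: the same change on two cores in this assay, a 10-fold higher number (1.00 log units; beyond the scatter) from compound 1 to compound 2 and a 2.0-fold lower number (0.30 log units; within the scatter) from compound 3 to compound 4, 20-fold (1.30 log units) apart, beyond the scatter of two such steps. Within the data shown here, with only two pairs, this shows that the step depends on its surroundings, but not which difference between the cores is responsible or how the change would behave on any further core.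

The compounds shown leave open how a hydroxyl group, an ethoxy group or an amine at the same place would read on either core. They also leave open whether the methoxy step on the core of compound 1 would recur with the entering group ortho to a methoxy group on another close analogue.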